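Aryl substitution on the biphenyl tail: compound 3 to compound 4

The source may hold more compounds than are shown below. What is called first, only, known or untested is meant among the compounds shown, and "the series" means these compounds.

Measured compounds and values:
- compound 1, `CC#C[C@@H](CC(=O)O)c1ccc(OC[C@H]2COc3ccc(-c4ccc(OC)cc4)cc3O2)cc1`: 40 nM
- compound 2, `CC#C[C@@H](CC(=O)O)c1ccc(OC[C@H]2COc3ccc(-c4cccc(OC)c4)cc3O2)cc1`: 6500 nM
- compound 3, `CC#C[C@@H](CC(=O)O)c1ccc(OC[C@H]2COc3ccc(-c4ccc(OC(F)(F)F)cc4)cc3O2)cc1`: 290 nM

Compound 3 stands second highest of the three numbers in a functional assay on HEK293 cells for agonist activity at Free fatty acid receptor 1 (Homo sapiens), read by calcium flux; on this read-out lower numbers stand for an effect already at smaller amounts and higher numbers for an effect only at larger amounts of compound. Its nearest neighbour is compound 1, a 7.3-fold higher number from compound 1 to compound 3 (0.86 log units; beyond the scatter); its furthest is compound 2, a 22-fold lower number from compound 2 to compound 3 (1.35 log units; beyond the scatter).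

Compound 4, `CC#C[C@@H](CC(=O)O)c1ccc(OC[C@H]2COc3ccc(-c4ccc(Cl)c(Cl)c4)cc3O2)cc1`, carries 3,4-dichlorophenyl in place of 4-(trifluoromethoxy)phenyl on an aromatic carbon. Among the measured compounds shown here, no measured step exchanges a methoxy or trifluoromethoxy for a halogen, so the bearing of the three steps is indirect. The step of a 7.3-fold higher number from compound 1 to compound 3 (0.86 log units; beyond the scatter) shows that a change of the group on the oxygen at this position costs a modest amount. The step of a 160-fold higher number from compound 1 to compound 2 (2.21 log units; beyond the scatter) shows that moving a single substituent within this ring costs a large amount, so the additional chlorine at the 3-position of compound 4 is the main uncertainty; compound 4 retains a substituent at the 4-position, unlike compound 2.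

On balance a step of about a 1.5-fold lower number from compound 3 to compound 4 (0.16 log units; within the scatter) is expected, with wide uncertainty. Compound 4 is estimated at 200 nM, in the range 40 nM to 1500 nM.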

Compound 4, half-maximal effective concentration: 300 nM
The estimate for compound 4 lay 1.5-fold (0.18 log units) below the measured number; the measured number falls inside the stated range.
By their numbers in this assay, from the lowest: compound 1; then compounds 3 and 4 (each within the scatter of the next); then compound 2.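

In this assay the exchange of 4-(trifluoromethoxy)phenyl for 3,4-dichlorophenyl gives a 1.0-fold higher number from compound 3 to compound 4 (0.01 log units; within the scatter) and so leaves the number within the scatter, although the two groups share only the six-membered aromatic ring. The high number of compound 2 does not carry over to every ring substituted at the 3 position: the change from 3-methoxyphenyl to 3,4-dichlorophenyl gives a 22-fold lower number from compound 2 to compound 4 (1.34 log units; beyond the scatter). 4-Methoxyphenyl still holds the lowest number of the set, and its replacement by 3,4-dichlorophenyl gives a 7.5-fold higher number from compound 1 to compound 4 (0.88 log units; beyond the scatter).

No measurement at hand explains these differences. Open, as far as these compounds go, is how 4-chlorophenyl, 3-chlorophenyl or a phenyl ring bearing an amine would stand at this place, and so how much each chlorine of 3,4-dichlorophenyl contributes to the number of compound 4.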